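Amine in place of the silyl ether on the stilbene

The source may hold more compounds than are shown below. What is called first, only, known or untested is meant among the compounds shown, and "the series" means these compounds.

Among the measured compounds shown here, compound 1 `COc1cc(/C=C\c2ccc(O[Si](C)(C)C(C)(C)C)cc2)cc(OC)c1` gives 50000 nM in a functional assay on HL-60 cells (Homo sapiens) for inhibition (on this read-out lower numbers stand for stronger inhibition and higher numbers for weaker inhibition), and stands with compound 2 `COc1cc(/C=C/c2ccc(O[Si](C)(C)C(C)(C)C)cc2)cc(OC)c1`, which gives 48000 nM, at the top of the numbers so far, the two within the scatter of each other; the step of a 1.0-fold lower number from compound 1 to compound 2 (0.02 log units; within the scatter) reflects nothing more than the fact that compounds 1 and 2 differ only in the configuration as drawn. Compound 3 `COc1cc(/C=C\c2ccc(N)cc2)cc(OC)c1` differs from compound 1 by one nitrogen atom in place of a group of 8 heavy atoms (6 carbon, 1 oxygen, 1 silicon; no ring), on an aromatic carbon. For the measured compounds named here, no measured step covers such an exchange, so this assay offers no guide to its size. For compound 3 a lower number is expected, the step of a 25-fold lower number from compound 1 to compound 3 (1.40 log units; beyond the scatter) reaching beyond the scatter. Compound 3 is estimated at 2000 nM, within 200 nM to 30000 nM.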

Compound 3, half-maximal inhibitory concentration: 2500 nM
Estimate against measurement, compound 3: 1.3-fold (0.10 log units) below; low and high end bracket the measured number.
By their numbers in this assay, from the lowest: compound 3; then compounds 2 and 1 (each within the scatter of the next).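

On this aromatic carbon the group matters: exchanging the silyl ether for amino gives a 20-fold lower number from compound 1 to compound 3 (1.30 log units; beyond the scatter) in this assay while the double bond stays Z. The earlier pair showed only that configuration made no difference with the silyl ether in place, whereas this change at the ring position moves the number beyond the scatter. Nothing at hand accounts for the size of this step.

Open, on these data alone, is whether a hydroxyl, a methoxy or an acetamide on this carbon would give a similar number. Also open, as far as these compounds go, is whether the E isomer of compound 3 would stay within the scatter of compound 3.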